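From a Sulfonic Acid to a Thiol on the Shared Core

The compounds below may be only part of what the source reports. "The series", "measured", "known", "first", "only" and "open" are said of these compounds alone.

Compound 1 `CCN(CC)C(=O)Cn1c(=N)sc2cc(OC(F)(F)F)ccc21`, compound 2 `N=c1sc2cc(OC(F)(F)F)ccc2n1CCS(N)(=O)=O` and compound 3 `N=c1sc2cc(OC(F)(F)F)ccc2n1CCS(=O)(=O)O` share one core and differ only in the group carried on the saturated chain carbon bound to an aromatic nitrogen. In a functional assay on the whole organism with Rattus norvegicus as the target (on this read-out lower numbers stand for an effect already at smaller amounts and higher numbers for an effect only at larger amounts of compound), compound 1 gives 9 mg/kg. In this assay compound 2 gives 6 mg/kg, which is a 1.5-fold lower number from compound 1 to compound 2 (0.18 log units; within the scatter). For compound 3 the read-out in this assay is only a limit, > 10 mg/kg, and so compound 3 is placed by the limit of > 10 mg/kg in this assay, at which 1 of the 3 values shown sits, rather than by a number. The step of an at least 1.1-fold higher number from compound 1 to compound 3 (0.04 log units; that floor lies within the scatter) and the step of an at least 1.6-fold higher number from compound 2 to compound 3 (0.22 log units; that floor lies within the scatter) are accordingly floors, not measured sizes.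

Compound 4 `N=c1sc2cc(OC(F)(F)F)ccc2n1CCS` has not been measured. It differs from compound 3 by sulfanyl in place of sulfo on a saturated chain carbon, two bonds along the chain from an aromatic nitrogen. Among the compounds with values here, no measured step exchanges sulfo for sulfanyl; the steps that bear on the change are the two ending at compound 3, both floors, and they show only that compound 3 sits at the limit while compound 1 and compound 2 sit at numbers. The chemist therefore expects compound 4 to return toward the region of those two numbers, the step of an at least 1.2-fold lower number from compound 3 to compound 4 (0.09 log units; that floor lies within the scatter) being the expected size, while a limit remains possible. The estimate for compound 4 in this assay is 8 mg/kg, expected to lie between 3 mg/kg and 30 mg/kg.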

Compound 4, dose for half-maximal effect: 2 mg/kg
Beside the measured number, compound 4's estimate is 4.0-fold (0.60 log units) above it; the whole stated range lies above it.
By their numbers in this assay, from the lowest: compound 4; then compounds 2 and 1 (each within the scatter of the next). At a limit, above all of these: compound 3.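

Within the data shown here, on the saturated chain carbon, two bonds along the chain from an aromatic nitrogen, sulfanyl gives the first steps on the shared core that lie beyond the scatter; every earlier step lay within it or had its floor within it. Set against sulfo, the change reads as an at least 5.0-fold lower number from compound 3 to compound 4 (0.69 log units; beyond the scatter), a floor and not a measured size, and set against sulfamoyl it reads as a 3.0-fold lower number from compound 2 to compound 4 (0.48 log units; beyond the scatter). Replacing diethylcarbamoyl with sulfanylmethyl gives a 4.5-fold lower number from compound 1 to compound 4 (0.65 log units; beyond the scatter), so that in this assay compound 4 stands lowest of the four, with its steps to all the others beyond the scatter.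

The compounds shown leave open whether this change depends on the sulfur itself or on the chain that carries it, a question that a hydroxy group, an amine or a methylthio group at the same place, or a longer chain ending in sulfanyl, would address. How far compound 3 truly lies from the others also stays unknown, as its read-out is only a limit: the limit of > 10 mg/kg in this assay, at which 1 of the 4 values shown sits.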